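The source may hold more compounds than are shown below. What is called first, only, known or untested is meant among the compounds shown, and "the series" means these compounds.

Three compounds have been measured in an assay for inhibition of Alpha amylase (Homo sapiens), with a stated time of 10 min; on this read-out higher numbers stand for weaker inhibition and lower numbers for stronger inhibition:

compound 1, `COc1cccc(-c2nc3ccccc3[nH]2)c1Cl`, giving 2740 nM;
compound 2, `COc1ccc(Br)c(-c2nc3ccccc3[nH]2)c1O`, giving 2480 nM;
compound 3, `COc1cccc(-c2nc3cc(F)ccc3[nH]2)c1Cl`, giving 2620 nM.

Compound 3 differs from compound 1 by one change, (fluoro in place of hydrogen on an aromatic carbon), and that step gave a 1.0-fold lower number from compound 1 to compound 3 (0.02 log units; within the scatter). Compound 2 carries a different core; how the core of compound 2 differs from the core of compound 1 is not broken down here. The values of compound 2, compound 1 and compound 3 all lie within the usual scatter of one another, so no order among them can be read from these numbers.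

Compound 4, `COc1ccc(Br)c(-c2nc3cc(F)ccc3[nH]2)c1O`, has not yet been measured. It differs from compound 2 by fluoro in place of hydrogen on an aromatic carbon, which is the same change as that from compound 1 to compound 3. For compound 4 the step expected in this assay is a 1.0-fold lower number from compound 2 to compound 4 (0.01 log units; within the scatter). This expectation rests on the earlier step, a 1.0-fold lower number from compound 1 to compound 3 (0.02 log units; within the scatter), which left the number essentially unchanged. Compound 4 is therefore estimated at 2450 nM, with a likely range from 1200 nM to 5000 nM.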

Compound 4, half-maximal inhibitory concentration: 2170 nM
The estimate for compound 4 lay 1.1-fold (0.05 log units) above the measured number; the range from low to high includes it.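

In this assay, among these compounds, fluoro in place of hydrogen on an aromatic carbon gave a 1.1-fold lower number from compound 2 to compound 4 (0.06 log units; within the scatter), so on the core of compound 2 this change again produced no step that can be read. Set beside the earlier step, the result on the two cores agrees: the same change on two cores in this assay, a 1.0-fold lower number (0.02 log units; within the scatter) from compound 1 to compound 3 and a 1.1-fold lower number (0.06 log units; within the scatter) from compound 2 to compound 4, 1.1-fold (0.04 log units) apart, within the scatter of two such steps. This shows that, for these two pairs, the near absence of an effect carried over from one core to the other, but because both steps lie within the scatter, it does not show that a measurable effect would transfer, nor does it predict the outcome on any other core in the series.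

The compounds shown leave open whether a different group at this same place, such as an amine, a nitrile or a carboxylic acid, would move the number beyond the scatter. They also leave open whether fluoro on another carbon of that ring would behave as it did here.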